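Heteroaryl swap at the fused core: pyrazolyl for thiazolyl

A few compounds are considered here, and "the series" means these few. Any claim that something is new, unique, unknown or untested is made for them only; others in the source may bear on it.

Of the compounds shown here, three have been measured in a functional assay on CHO cells for agonist activity at Alpha-1A adrenergic receptor (Homo sapiens), read by FLIPR and calcium flux; a lower number here means a smaller maximal response, a higher number a larger maximal response. Compound 1 `c1cncc(-c2cccc3c2CCC3c2ncc[nH]2)c1` gives 36%. Compound 2 `Cc1oncc1-c1cccc2c1CCC2c1ncc[nH]1` gives 63%. Compound 3 `c1cc(-c2nccs2)c2c(c1)C(c1ncc[nH]1)CC2` gives 64%. On these numbers compound 3 stands at the top of the three, but compound 2 lies within the scatter of it, so the two cannot be told apart; only compound 1 sits clearly lower, by a number 28 percentage points higher from compound 1 to compound 3 (beyond the scatter).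

The next compound is compound 4 `c1cc(-c2cn[nH]c2)c2c(c1)C(c1ncc[nH]1)CC2`, which differs from compound 3 in one place: 1H-pyrazol-4-yl in place of 1,3-thiazol-2-yl on an aromatic carbon. A five-membered aromatic ring with two hetero atoms is kept on the same aromatic carbon of the six-membered ring.

The step that bears most directly on this change is a number 1 percentage points higher from compound 2 to compound 3 (within the scatter), an exchange of one five-membered heteroaryl for another. The two larger steps, a number 27 percentage points higher from compound 1 to compound 2 (beyond the scatter) and a number 28 percentage points higher from compound 1 to compound 3 (beyond the scatter), each replace a six-membered pyridin-3-yl with a five-membered ring and do not describe the present change. Among the measured compounds shown here, no step yet shows a hydrogen-bond donor entering at this position.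

On this basis no step beyond the scatter is expected; compound 4 is estimated at 58%, with a range of 40% to 76%, meaning an expected step of a number 6 percentage points lower from compound 3 to compound 4 (within the scatter).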

Compound 4, largest response reached (Emax), in percent of the reference or control that the assay uses: 84%
Estimate against measurement, compound 4: 26 percentage points below, and the stated range ends below it.
By their numbers in this assay, from the lowest: compound 1; then compounds 2 and 3 (each within the scatter of the next); then compound 4.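

Notes on the position: in this assay, this aromatic carbon ortho to a fused ring had looked indifferent to the choice of five-membered heteroaryl, with a number 1 percentage points higher from compound 2 to compound 3 (within the scatter), but a number 20 percentage points higher from compound 3 to compound 4 (beyond the scatter) and a number 21 percentage points higher from compound 2 to compound 4 (beyond the scatter) show that it does discriminate among such rings. The exchange of 1,3-thiazol-2-yl for 1H-pyrazol-4-yl keeps 5 heavy atoms and a five-membered aromatic ring with 2 hetero atoms, while going from 0 hydrogen-bond donors to 1 hydrogen-bond donor, so ring size and hetero atom count alone do not set the response here, and a number 48 percentage points higher from compound 1 to compound 4 (beyond the scatter) is the largest step in the set. Nothing measured on these compounds accounts for the gain.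

Open, as far as these compounds go, is how 1-methyl-1H-pyrazol-4-yl would compare with 1H-pyrazol-4-yl at this carbon, a comparison that would separate the ring itself from the hydrogen on its nitrogen. Also open, from the compounds shown here alone, is whether a non-ring group such as a carboxamide or an aminomethyl on the same carbon would keep the response of compound 4 at 84%.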